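Swapping bromo for iodo on a halogenated chromene core

The source may report more compounds than this note shows. Statements on the series, on what has been measured and on what is new or still open speak of the compounds shown alone.

Measured compounds:
- compound 1, `CC[Si](C#Cc1ccc2c(c1)C=C([N+](=O)[O-])C(C(F)(F)F)O2)(CC)CC`, 4940 nM
- compound 2, `O=[N+]([O-])C1=Cc2cc(Br)ccc2OC1C(F)(F)F`, 20200 nM
- compound 3, `O=[N+]([O-])C1=Cc2cccc(Cl)c2OC1C(F)(F)F`, 15200 nM

All three were tested in an assay on 1321N1 cells for antagonist activity at P2Y purinoceptor 6 (Mus musculus), read by FLIPR and calcium flux; a higher number here means a weaker inhibitor, a lower number a stronger inhibitor. Compound 2 has the highest of the three numbers. Its nearest neighbour is compound 3, whose number lies within the usual scatter of compound 2, so the two cannot be told apart. Compound 1 stands furthest away, with a number beyond the scatter below that of compound 2.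

The next compound to be measured is compound 4, `O=[N+]([O-])C1=Cc2cc(I)ccc2OC1C(F)(F)F`. Compared with compound 2 it carries iodo in place of bromo on an aromatic carbon. The change is confined to that one aromatic carbon: iodo takes the place of bromo, and nothing else on the shared core moves.

Among the measured compounds shown here, no pair of measured compounds differing in a single place is available to calibrate this swap. The expectation is a step in this assay that stays within the scatter, or at most a slightly lower number, giving an estimated change of a 1.4-fold lower number from compound 2 to compound 4 (0.16 log units; within the scatter). Compound 4 is therefore estimated at 14000 nM, within a range from 5000 nM to 40000 nM.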

Compound 4, half-maximal inhibitory concentration: 28700 nM
The estimate for compound 4 lay 2.1-fold (0.31 log units) below the measured number; low and high end bracket the measured number.
By their numbers in this assay, from the lowest: compound 1; then compounds 3, 2 and 4 (each within the scatter of the next).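

Iodo in place of bromo on this aromatic carbon, which sits meta to a fused ring and para to a fused ring, gives a 1.4-fold higher number from compound 2 to compound 4 (0.15 log units; within the scatter) in this assay, a step within the usual scatter. Among the compounds shown here, this is the first pair in the set that differs in one place, and it shows that these two halogens cannot be told apart here: exchanging one for the other leaves the inhibitor's strength unresolved in this assay. No measurement bears on why the two behave alike.

Steps to compound 1 and compound 3 cannot be read, so this pair is the only direct comparison available. As far as these compounds go, whether a very different group on the same aromatic carbon, such as an amine, a carboxylic acid or a nitrile, would give a number beyond the scatter remains open.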